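The compounds below may be only part of what the source reports. "The series", "measured", "known", "first", "only" and "open" are said of these compounds alone.

Measured in a functional assay on HeLa cells (Homo sapiens) for inhibition, read by CCK-8 assay, with a stated time of 48 h; on this read-out lower numbers stand for stronger inhibition and higher numbers for weaker inhibition:
- Compound 1 `O=S(=O)(NCCNC(=S)Nc1cc(C(F)(F)F)cc(C(F)(F)F)c1)c1ccc(-c2ccccc2OCc2cccc(O)c2)s1`: 14900 nM
- Compound 2 `O=C(NCCNS(=O)(=O)c1ccc(-c2ccccc2O[C@H]2CC[C@H](O)CC2)s1)Nc1cc(C(F)(F)F)cc(C(F)(F)F)c1`: > 20000 nM (a limit)
- Compound 3 `COc1ccc(Oc2ccc([N+](=O)[O-])cc2-c2ccsc2S(=O)(=O)N2CCN(C(=O)Nc3ccc([N+](=O)[O-])cc3)CC2)cc1OC`: > 50000 nM (a limit)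

Only compound 1 gives an actual number. Compound 3 stands at a limit of the assay, > 50000 nM. Compound 2 also stands at a limit and not at a number, > 20000 nM.

Compound 4 `O=C(NCCNS(=O)(=O)c1ccc(-c2ccccc2O[C@H]2CC[C@@H](O)CC2)s1)Nc1cc(C(F)(F)F)cc(C(F)(F)F)c1` has the same atoms and bonds as compound 2 and differs only in configuration as drawn: the two compounds have the same atoms and bonds and differ only in configuration as drawn: 2 of 2 stereo elements differ (all stereocentres are inverted: mirror images); a stereocentre at a saturated ring carbon is drawn r in compound 2 and s in compound 4; a stereocentre at a saturated ring carbon is drawn r in compound 2 and s in compound 4. Among the compounds with values here, no measured pair shows what such a change does in this assay. The expected step that the limit leaves unreadable from compound 2 to compound 4 is none beyond the scatter, with no favoured direction. That expectation rests on compound 2, whose limit is > 20000 nM. For compound 4 the estimated value is 22000 nM, with an expected range of 10000 nM to 45000 nM.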

Compound 4, half-maximal inhibitory concentration: 14100 nM
For compound 4 the middle estimate is 1.6-fold (0.19 log units) above the measured one; the measured number falls inside the stated range.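

With only the configuration as drawn changed at the two saturated ring carbons, this assay shows an at least 1.4-fold lower number from compound 2 to compound 4 (0.15 log units; that floor lies within the scatter). Compound 2 still stands at a limit, > 20000 nM, so the true size of this step cannot be read. Compound 4 does give an actual number, which places one stereoisomer of this pair on the scale and ties any gap to a single source: the fact that compounds 2 and 4 differ only in the configuration as drawn

The compounds shown leave open how large that gap really is. They also leave open whether an amine or a carboxylic acid on that saturated ring would shift the number.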